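Swapping a Phenyl for tert-Butoxy on a Kinase Inhibitor

The source may report more compounds than this note shows. Statements on the series, on what has been measured and on what is new or still open speak of the compounds shown alone.

Of the compounds shown here, three have been measured in an assay on isolated protein for inhibition of protein kinase C theta type (Homo sapiens), read by TR-FRET, with a stated time of 2 h; a higher number here means a weaker inhibitor, a lower number a stronger inhibitor. Compound 1 `N#Cc1cnc(NCc2cnccc2C(F)(F)F)cc1NC[C@H]1C[C@H](O)C1` gives 700 nM, compound 2 `N#Cc1cnc(NCc2cncnc2C(F)(F)F)cc1N[C@H]1CC[C@@H](O)CC1` gives 450 nM, and compound 3 `N#Cc1cnc(NCc2cncnc2-c2ccccc2)cc1N[C@H]1CC[C@@H](O)CC1` gives 90 nM, the lowest of the three numbers in this assay, with compound 2 nearest and compound 1 furthest from it.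

Compound 4 `CC(C)(C)Oc1ncncc1CNc1cc(N[C@H]2CC[C@@H](O)CC2)c(C#N)cn1` is not yet measured. It differs from compound 3 in one place: tert-butoxy in place of phenyl on an aromatic carbon. Going by the values given here, only one earlier step speaks to this position: a 5.0-fold lower number from compound 2 to compound 3 (0.70 log units; beyond the scatter). Among the compounds with values here, that step shows the group at this carbon can move the number well beyond the scatter, but no measured compound carries tert-butoxy or any group resembling it, so its effect is unknown. Because a 5.0-fold lower number from compound 2 to compound 3 (0.70 log units; beyond the scatter) marks phenyl as the better of the two groups tried so far, a step back toward the number of compound 2 is expected, so that a 2.8-fold higher number from compound 3 to compound 4 (0.44 log units; beyond the scatter) is the estimated step. Compound 4 is therefore expected to give about 250 nM in this assay, within a range of 80 nM to 800 nM.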

Compound 4, half-maximal inhibitory concentration: 200 nM
Estimate against measurement, compound 4: 1.3-fold (0.10 log units) above, and the stated range covers the measured number.
By their numbers in this assay, from the lowest: compound 3; then compound 4; then compounds 2 and 1 (each within the scatter of the next).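

In this assay, going by these compounds alone, tert-butoxy, the first group at this carbon to carry an oxygen, takes the middle place among the three groups tried, with a 2.2-fold higher number from compound 3 to compound 4 (0.35 log units; beyond the scatter) and a 2.3-fold lower number from compound 2 to compound 4 (0.35 log units; beyond the scatter) as the two steps that fix it there. This shows that an aromatic ring at this carbon is not required for a lower number than trifluoromethyl gives, while phenyl still gives the lowest number of the three. Nothing available explains why the groups fall in this order.

On these data alone, it remains open whether a smaller ether such as methoxy, an amine, or a phenyl ring bearing a fluorine would do better at this carbon. The compounds shown also cannot tell whether the same order would hold with the side chain of compound 1 in place of the hydroxycyclohexyl group.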